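The source may hold more compounds than are shown below. What is called first, only, known or untested is meant among the compounds shown, and "the series" means these compounds.

In an assay on cells (Hepatocyte) for inhibition of glucokinase regulatory protein (Mus musculus), with stated times of 20 min and 40 min (a lower number here means that less compound is needed, a higher number that more compound is needed for the effect), compound 1 `CC#CCC(O)(c1ccc(N2CCN(S(=O)(=O)c3ccc(N)nc3)C[C@@H]2C#CC)cc1)C(F)(F)F` gives 137 nM and compound 2 `CC#C[C@H]1CN(S(=O)(=O)c2ccc(N)nc2)CCN1c1ccc([C@](O)(CO)C(F)(F)F)cc1` gives 98 nM; compound 2 thus holds the smaller of the two numbers, yet the step from compound 1 to compound 2 (a 1.4-fold lower number from compound 1 to compound 2 (0.15 log units; within the scatter)) lies within the scatter. Compound 3 `CC#C[C@H]1CN(S(=O)(=O)c2ccc(N)nc2)CCN1c1ccc([S+](C)[O-])cc1` carries a group of 3 heavy atoms (1 carbon, 1 oxygen, 1 sulfur; no ring) in place of a group of 8 heavy atoms (3 carbon, 2 oxygen, 3 fluorine; no ring), on an aromatic carbon. Within the data shown here, the single measured step bears on it only loosely: it too exchanges the group on that aromatic carbon, and it moved this assay little. Among the measured compounds shown here, no closer precedent exists. The shift expected for compound 3 is a 1.5-fold higher number from compound 2 to compound 3 (0.18 log units; within the scatter), not clearly beyond the scatter. The estimate for compound 3 is therefore 150 nM, with a range of 40 nM to 600 nM.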

Compound 3, half-maximal effective concentration: > 12500 nM
Compound 3 was reported as a limit (the forecaster's own chance of this, stated with the estimate: 5%); middle value at least 83-fold (1.92 log units) from the limit.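

In this assay, the aromatic carbon para to a large group proves far less permissive than the earlier step suggested: replacing 1,2-dihydroxy-1-(trifluoromethyl)ethyl with the small group of sulfur, oxygen and carbon gives an at least 120-fold higher number from compound 2 to compound 3 (2.10 log units; beyond the scatter). The same exchange starting from the group of compound 1 gives an at least 91-fold higher number from compound 1 to compound 3 (1.96 log units; beyond the scatter). Compound 3 is reported only as a limit: the limit of > 12500 nM in this assay, at which 1 of the 3 values shown sits.

Still open, from the compounds shown here alone, is whether the hydroxyl groups, the trifluoromethyl or the overall size of the group accounts for the difference. A hydroxymethyl, a carboxylic acid or a primary amide at this carbon would help separate these.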